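Pyrazole Esters of Substituted Phenols Tested on Raji Cells

The compounds below may be only part of what the source reports. "The series", "measured", "known", "first", "only" and "open" are said of these compounds alone.

Three esters share one core and differ only in the phenol that is attached through an oxygen next to a carbonyl group. Compound 1 `COc1ccc(OC(=O)c2cn(-c3ccccc3)nc2-c2ccncc2)cc1` carries a 4-methoxyphenyl group, compound 2 `CC(C)c1cccc(OC(=O)c2cn(-c3ccccc3)nc2-c2ccncc2)c1` a 3-isopropylphenyl group, and compound 3 `CC(C)(C)c1ccc(OC(=O)c2cn(-c3ccccc3)nc2-c2ccncc2)cc1` a 4-(tert-butyl)phenyl group. They were examined in a functional assay on Raji cells (Homo sapiens) for cytotoxicity, read by MTT assay, with a stated time of 48 h; on this read-out lower numbers stand for stronger inhibition and higher numbers for weaker inhibition. In this assay compound 1 reached only a limit, recorded as > 100000 nM. Compound 2 stands without a number of its own in this assay; its entry reads "nd(insoluble)" (no result reported), so no result was reported. Among the compounds with values here, the one further value in the table is a limit, (the limit of > 100000 nM in this assay, at which 1 of the 2 values shown sits), and that is all the measured material available.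

Compound 3 arises from compound 2 by 4-(tert-butyl)phenyl in place of 3-isopropylphenyl on an oxygen next to a carbonyl group. Within the data shown here, no measured step connects these two compounds, and compound 2 offers no starting number, so the size of the change in this assay cannot be judged from data. Given that compound 1 returned only a limit, compound 3 is expected to land near 100000 nM, with a plausible span from 30000 nM to 300000 nM, and it may well report a limit rather than a number.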

Compound 3, half-maximal inhibitory concentration: 33300 nM
Estimate against measurement, compound 3: 3.0-fold (0.48 log units) above; low and high end bracket the measured number.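

Compound 3 gives the only actual number among these esters, so in this assay a change to the phenol part can move the result from a limit to a measured value. With the shared core left untouched, tert-butyl in place of methoxy on an aromatic carbon gives an at least 3.0-fold lower number from compound 1 to compound 3 (0.47 log units; beyond the scatter) in this comparison, a change that is modest but beyond the usual scatter and the first sign that this part of the molecule affects the read-out. The real size of the step may be larger than the printed figure, since one end of the comparison is not a number but a limit: the limit of > 100000 nM in this assay, at which 1 of the 3 values shown sits.

Any step involving compound 2 cannot be read, so these compounds do not show how 4-(tert-butyl)phenyl compares with 3-isopropylphenyl, and two end points cannot establish a trend across the phenol groups. As far as these compounds go, it also remains open whether a phenol carrying an amine, a carboxylic acid or a longer chain would push the number lower still or return it to a limit, and the data give no reason for the change seen here.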